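Swapping a Naphthyl Arm for a Hydroxyquinolinyl Arm

A few compounds are considered here, and "the series" means these few. Any claim that something is new, unique, unknown or untested is made for them only; others in the source may bear on it.

Three compounds share one large fused core and differ only in the aromatic group attached to it. Compound 1 `Cc1nc2c3ccccc3ccc2c2nc3c(ccc4ccccc43)c(-c3nccnc3N)c12` carries a 3-aminopyrazin-2-yl group; in a functional assay, read by spectrophotometry, with a stated time of 15 min (a higher number here means a weaker inhibitor, a lower number a stronger inhibitor), compound 1 gives 47.8 ug/mL. Compound 2 `COc1ccc(-c2c3ccc4ccccc4c3nc3c2c(C)nc2c4ccccc4ccc32)cc1` carries a 4-methoxyphenyl group, and in this assay compound 2 gives 82.3 ug/mL. Compound 3 `Cc1nc2c3ccccc3ccc2c2nc3c(ccc4ccccc43)c(-c3cccc4ccccc34)c12` carries a naphthalen-1-yl group, and in this assay compound 3 gives 64.3 ug/mL, the second highest of the three numbers. The steps among them are all small: a 1.3-fold higher number from compound 1 to compound 3 (0.13 log units; within the scatter) and a 1.3-fold lower number from compound 2 to compound 3 (0.11 log units; within the scatter), and likewise a 1.7-fold higher number from compound 1 to compound 2 (0.24 log units; within the scatter). Compound 4 `Cc1nc2c3ccccc3ccc2c2nc3c(ccc4ccccc43)c(-c3cc(O)nc4ccccc34)c12` is the next member: 2-hydroxyquinolin-4-yl in place of naphthalen-1-yl on an aromatic carbon. The two steps that bear on this change, the ones ending at compound 3, show that exchanging one aromatic arm for another of quite different make-up has so far not moved the number beyond the scatter. No step beyond the scatter is therefore expected here either, in either direction, although a group carrying a hydroxyl and a ring nitrogen at this position has not been tried before. The step expected is a 1.1-fold lower number from compound 3 to compound 4 (0.03 log units; within the scatter). Compound 4 is expected to give about 60 ug/mL in this assay, most likely between 30 ug/mL and 120 ug/mL.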

Compound 4, half-maximal inhibitory concentration: 44.8 ug/mL
Compound 4: the middle estimate sits 1.3-fold (0.13 log units) above what was measured; the measured number falls inside the stated range.
By their numbers in this assay, from the lowest: compounds 4, 1, 3 and 2 (each within the scatter of the next).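

Earlier arms at this position had not included a group with a hydroxyl and a ring nitrogen, and in this assay putting 2-hydroxyquinolin-4-yl on this aromatic carbon, opposite the ring nitrogen, gives a 1.4-fold lower number from compound 3 to compound 4 (0.16 log units; within the scatter) and stays within the scatter. The comparisons with the other two arms agree, with a 1.8-fold lower number from compound 2 to compound 4 (0.26 log units; within the scatter) and a 1.1-fold lower number from compound 1 to compound 4 (0.03 log units; within the scatter) also within the scatter. Naphthalen-1-yl has no hydrogen-bond donors or acceptors and 2-hydroxyquinolin-4-yl has both, yet this difference comes with no step that can be told from the scatter, and no supporting data offer an explanation for the closeness of the four numbers.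

From the compounds shown here alone, all four arms are ring groups attached directly to the shared core, so it remains open whether an amine, a carboxylic acid or a longer alkyl chain at this position would give a step beyond the scatter. Going by these compounds, it also remains open how a plain quinolin-4-yl arm, without the hydroxyl, would compare with 2-hydroxyquinolin-4-yl in this assay.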